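Working notes on cytotoxicity across the shared core

The compounds below may be only part of what the source reports. "The series", "measured", "known", "first", "only" and "open" are said of these compounds alone.

Three compounds on the shared core have so far been run in an ADME assay on MT4 cells (Homo sapiens) for cytotoxicity, read by MTT assay; on this read-out higher numbers stand for lower toxicity in this test and lower numbers for higher toxicity in this test. Compound 1 `COC(=O)c1sccc1NC(=O)CSc1nncnc1-c1ccccc1Cl` gives 105000 nM in this assay. Compound 2 `COC(=O)c1ccc(NC(=O)CSc2nncnc2-c2ccccc2Cl)c(Br)c1` gives 59000 nM in this assay, and compound 3 `Cc1ccc(NC(=O)CSc2nncnc2-c2ccccc2Cl)c([N+](=O)[O-])c1` gives 158000 nM in this assay. Compound 1 holds the second highest of the three numbers; its gap to compound 3 lies within the scatter, as does its gap to compound 2, so none of the three can be set apart from the others on cytotoxicity in this assay. Going by the values given here, no pair of the measured compounds differs in only one place, so no step between measured compounds is available to read from.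

Compound 4 `O=C(CSc1nncnc1-c1ccccc1Cl)Nc1ccccc1Cl` is not yet measured. It differs from compound 1 in one place: 2-chlorophenyl in place of 2-(methoxycarbonyl)thiophen-3-yl on an amide-type nitrogen. Among the compounds with values here, the measured set gives no step that isolates this exchange, and the measured values of compound 1, compound 2 and compound 3 sit close together across rather different groups on the amide-type nitrogen. The expectation is therefore a step of a 1.1-fold lower number from compound 1 to compound 4 (0.02 log units; within the scatter), that is, none beyond the scatter in either direction. Compound 4 is accordingly estimated at 100000 nM in this assay, with a range from 40000 nM to 250000 nM.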

Compound 4, half-maximal cytotoxic concentration: 90000 nM
For compound 4 the middle estimate is 1.1-fold (0.05 log units) above the measured one; measured number inside the range.
By their numbers in this assay, from the lowest: compounds 2, 4, 1 and 3 (each within the scatter of the next, the first and the last beyond it).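

Going by these compounds alone, the exchange of 2-(methoxycarbonyl)thiophen-3-yl for 2-chlorophenyl on the amide-type nitrogen provides the first step that can be read at one place in this assay: a 1.2-fold lower number from compound 1 to compound 4 (0.07 log units; within the scatter). Within the data shown here, in this one pair, the five-membered aromatic ring with its hetero atom, the double bond outside aromatic rings and the hydrogen-bond acceptors counted for the leaving group all depart, and a six-membered aromatic ring of carbon only bearing chlorine enters, without a step beyond the scatter, which the earlier compounds, differing in more than one place, could not show. Nothing at hand bears on why this exchange leaves the number within the scatter.

As far as these compounds go, it remains open whether the number would also hold with a group of another kind on the amide-type nitrogen, such as a cyclohexyl ring, a longer alkyl chain or a phenyl ring carrying an amine. From the compounds shown here alone, it is equally open whether a carboxylic acid in place of the methyl ester of compound 1 would give a step beyond the scatter.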